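Permeability of a tetrafluorophenyl-to-phenoxy series and a trifluorophenyl analogue

This account rests on a few compounds, and the source may have more. Where it says the series, first, only, none or still open, it means among the compounds named here.

Measured so far:
Compound 1 `Cc1c(CCCC(=O)O)c2cccc(/C=C/c3ccc(OCCCCc4c(F)c(F)cc(F)c4F)cc3)c2n1CC(=O)O`: 9.4 10^-6 cm/s
Compound 2 `Cc1c(CCCC(=O)O)c2cccc(/C=C/c3ccc(OCCCCc4c(F)cc(F)c(F)c4F)cc3)c2n1CC(=O)O`: 2.9 10^-6 cm/s
Compound 3 `O=C(O)CCCc1cn(CC(=O)O)c2c(/C=C/c3ccc(OCCCCOc4ccccc4)cc3)cccc12`: 1.6 10^-6 cm/s

In a physicochemical assay for permeability, using PAMPA, with a stated time of 4 h, at pH 6.2, tested at 50 uM (on this read-out higher numbers stand for higher permeability and lower numbers for lower permeability), compound 3 gives the lowest of the three numbers; compound 2 lies within the scatter of it, whereas compound 1 stands clearly higher. Compound 4 `O=C(O)CCCc1cn(CC(=O)O)c2c(/C=C/c3ccc(OCCCCc4c(F)ccc(F)c4F)cc3)cccc12` differs from compound 3 by 2,3,6-trifluorophenyl in place of phenoxy on a saturated chain carbon, four bonds along the chain from an oxygen on an aromatic ring. Among the measured compounds shown here, no measured step covers this exact change; compounds 1 and 2 carry fluorinated phenyl groups at the same place but also differ from compound 3 elsewhere, so they give only a loose pointer. For the measured compounds named here, the one measured step, a 3.2-fold lower number from compound 1 to compound 2 (0.51 log units; beyond the scatter), shows that the fluorine pattern alone can shift the number modestly. Compound 4 is therefore expected to show a modest rise, a 2.0-fold higher number from compound 3 to compound 4 (0.30 log units; within the scatter), with a wide range. The estimate for compound 4 is 3.2 10^-6 cm/s, between 1.2 10^-6 cm/s and 8.5 10^-6 cm/s.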

Compound 4, apparent permeability: 1.4 10^-6 cm/s
The estimate for compound 4 lay 2.3-fold (0.36 log units) above the measured number, within the range that was stated.
By their numbers in this assay, from the lowest: compounds 4, 3 and 2 (each within the scatter of the next, the first and the last beyond it); then compound 1.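

In this assay, a 1.1-fold lower number from compound 3 to compound 4 (0.06 log units; within the scatter) comes with 2,3,6-trifluorophenyl in place of phenoxy on a saturated chain carbon, four bonds along the chain from an oxygen on an aromatic ring. On this core, then, the exchange of the two groups does not separate the compounds, which compounds 1 and 2, differing from compound 3 elsewhere too, could not show. Nothing available here accounts for this result. Still open, from the compounds shown here alone, is whether an amine or a longer chain at this place would move the number, and whether the same exchange would read alike on the core of compound 1.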